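Amidine series: methoxy to hydrogen, cytotoxicity expectation

The compounds below may be only part of what the source reports. "The series", "measured", "known", "first", "only" and "open" are said of these compounds alone.

Measured so far:
compound 1 `N=C(N)c1ccc(-c2ccc(-c3cc(Cl)cc(Cl)c3)s2)s1`: 75800 nM
compound 2 `COc1ccc(-c2ccc(-c3ccc(C(=N)N)o3)o2)cc1`: 20400 nM
compound 3 `N=C(N)c1ccc(-c2ccc(-c3ccc(Cl)cc3)s2)s1`: 29500 nM

In a functional assay on cells (Panel NCI-60 (60 carcinoma cell lines), Homo sapiens) for inhibition, read by sulforhodamine B assay, with a stated time of 48 h (on this read-out lower numbers stand for higher toxicity in this test and higher numbers for lower toxicity in this test), compound 2 gives the lowest of the three numbers. Compound 3 sits within the scatter of compound 2, so no order between the two can be read; compound 1 stands beyond the scatter, with the higher number. Compound 4 `N=C(N)c1ccc(-c2ccc(-c3ccccc3)o2)o1` is not yet measured and differs from compound 2 by hydrogen in place of methoxy on an aromatic carbon. Among the compounds with values here, no pair of measured compounds differs in one place, so the size of this change has no precedent. The step from compound 2 to compound 4 is expected to be small, a 1.5-fold higher number from compound 2 to compound 4 (0.17 log units; within the scatter), with no direction beyond the scatter. For compound 4 the estimate in this assay is 30000 nM, between 10000 nM and 90000 nM.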

Compound 4, concentration lethal to 50% of the cells: 22400 nM
Compound 4: middle estimate off by 1.3-fold (0.13 log units), on the high side, and the stated range covers the measured number.
By their numbers in this assay, from the lowest: compounds 2, 4 and 3 (each within the scatter of the next); then compound 1.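

Within the data shown here, replacing methoxy by hydrogen on this aromatic carbon, para to a large group, gives the first single-place step in this assay, a 1.1-fold higher number from compound 2 to compound 4 (0.04 log units; within the scatter). At this position, then, the methoxy can be lost with no change that this read-out can resolve. No available evidence bears on why the step is this small.

Going by these compounds, whether an amine, a carboxylic acid or a longer chain on this carbon would move the number beyond the scatter stays open. Also open, on these data alone, is whether the same change would stay this small on the core of compound 3.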